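Removing 4-methyl-1,4-diazepan-1-yl from compound 1

This account rests on a few compounds, and the source may have more. Where it says the series, first, only, none or still open, it means among the compounds named here.

Measured in a functional assay on NCI-H1581 cells (Homo sapiens) for antiproliferative activity, read by CCK-8 assay, with a stated time of 72 h; on this read-out higher numbers stand for weaker inhibition and lower numbers for stronger inhibition:
- Compound 1 `COc1cc(OC)c(Cl)c(-c2ccc3c(NC(=O)c4ccc(N5CCCN(C)CC5)cc4)n[nH]c3n2)c1Cl`: 1.3 nM
- Compound 2 `COc1cc(C(=O)Nc2n[nH]c3nc(-c4c(Cl)c(OC)cc(OC)c4Cl)ccc23)ccc1N1CCN(C)CC1`: 15.6 nM

Of these two, compound 1 has the lower number and so the stronger inhibition, and the gap to compound 2 lies beyond the scatter. Compound 3 `COc1cc(OC)c(Cl)c(-c2ccc3c(NC(=O)c4ccccc4)n[nH]c3n2)c1Cl` is not yet measured. It carries hydrogen in place of 4-methyl-1,4-diazepan-1-yl on an aromatic carbon and is otherwise the same as compound 1. Among the measured compounds shown here, no measured pair shows this change alone, so what follows is a judgement. In this assay the estimated step of a 46-fold higher number from compound 1 to compound 3 (1.66 log units; beyond the scatter) is a rise beyond the scatter, meaning weaker inhibition. For compound 3 the expected value is 60 nM with an estimated range of 12 nM to 400 nM at most likely.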

Compound 3, half-maximal inhibitory concentration: > 1000 nM
Compound 3: only a limit was reported (the forecaster's own chance of this, stated with the estimate: 5%); at least 16-fold (1.22 log units) between middle value and limit.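

In this assay, compound 3 gives > 1000 nM, which is a limit of the assay and not a number. Among the compounds shown here, no earlier compound showed this aromatic carbon without a large group. Here, hydrogen in place of 4-methyl-1,4-diazepan-1-yl gives an at least 760-fold higher number from compound 1 to compound 3 (2.88 log units; beyond the scatter), so inhibition in this series depends strongly on having a group at this place. The compounds shown leave open which part of that group matters. A plain dimethylamino group or a morpholine ring at this place could show whether a smaller amine or a different ring would bring inhibition back.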